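From bromo to fluoro on the shared core

The source may report more compounds than this note shows. Statements on the series, on what has been measured and on what is new or still open speak of the compounds shown alone.

For the measured compounds named here, in a functional assay on thoracic aorta (Rattus norvegicus, strain Wistar), with a stated time of 15 min (on this read-out lower numbers stand for an effect already at smaller amounts and higher numbers for an effect only at larger amounts of compound), compound 2 `CCOc1ccc(Br)cc1C(C)NC(=O)N(C)S(=O)(=O)c1ccccc1` gives 19800 nM, the only actual number so far. Compound 1 `CCOc1ccc(F)cc1C(C)NC(=O)NS(=O)(=O)c1ccccc1` shows > 300000 nM, which is a limit of the assay and not a number. Compound 3 `CCOc1ccc(F)cc1C(C)NC(=O)N(C)S(=O)(=O)c1ccccc1` is still unmeasured and differs from compound 2 in one place: fluoro in place of bromo on an aromatic carbon. Going by the values given here, no measured pair shows this change alone, so only a modest shift towards higher numbers in this assay is expected. The expected change is a 2.0-fold higher number from compound 2 to compound 3 (0.31 log units; beyond the scatter). Compound 3 is estimated at 40000 nM, within a range of 10000 nM to 160000 nM.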

Compound 3, half-maximal effective concentration: 11500 nM
Compound 3: the middle estimate sits 3.5-fold (0.54 log units) above what was measured; measured number inside the range.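

Fluoro in place of bromo, para to an ethoxy group, gives a 1.7-fold lower number from compound 2 to compound 3 (0.24 log units; within the scatter) in this assay, so the two halogens cannot be told apart at this position. The large change lies elsewhere: methyl in place of hydrogen on the amide-type nitrogen gives an at least 26-fold lower number from compound 1 to compound 3 (1.41 log units; beyond the scatter) in this assay. For compound 1, that comparison rests on a limit of the assay and not a number: the limit of > 300000 nM in this assay, at which 1 of the 3 values shown sits.

From the compounds shown here alone, whether an amine or a methoxy group at this aromatic position would fit with fluoro and bromo stays open. So does whether an ethyl group on that nitrogen would keep the lower number.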